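Exchanging the aryl group on the piperazine of compound 3

The compounds below may be only part of what the source reports. "The series", "measured", "known", "first", "only" and "open" are said of these compounds alone.

Measured compounds in an assay on brain for binding affinity to Adrenergic receptor alpha-1 (Rattus norvegicus); a lower number here means a stronger inhibitor, a higher number a weaker inhibitor:
compound 1, `COc1cc2nc(N3CCN(c4cnccn4)CC3)nc(N)c2cc1OC`, gives 0.18 nM
compound 2, `COc1cc2nc(N3CCN(c4nccc(C)n4)CC3)nc(N)c2cc1OC`, gives 0.92 nM
compound 3, `COc1cc2nc(N3CCN(c4cc(OC(C)C)ncn4)CC3)nc(N)c2cc1OC`, gives 0.18 nM

On these numbers compound 3 stands level with compound 1 at the digits shown, the two together the lowest of the three, while compound 2 sits a 5.1-fold lower number from compound 2 to compound 3 (0.71 log units; beyond the scatter) away. Compound 4, `COc1nc(OC)nc(N2CCN(c3nc(N)c4cc(OC)c(OC)cc4n3)CC2)n1`, differs from compound 3 by 4,6-dimethoxy-1,3,5-triazin-2-yl in place of 6-isopropoxypyrimidin-4-yl on an amine nitrogen in a ring. The aryl exchanges seen so far bear on this: no change at the digits printed from compound 1 to compound 3 (within the scatter), whereas a 5.1-fold higher number from compound 1 to compound 2 (0.71 log units; beyond the scatter). A swap of the aryl on this ring nitrogen has therefore moved this assay either not at all or modestly. For compound 4 a small shift, a 1.7-fold higher number from compound 3 to compound 4 (0.22 log units; within the scatter), is expected. Compound 4 is estimated at 0.3 nM, within 0.1 nM to 1 nM.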

Compound 4, inhibition constant: 0.08 nM
Estimate against measurement, compound 4: 3.8-fold (0.57 log units) above; measured number below the stated range.
By their numbers in this assay, from the lowest: compound 4; then compounds 1 and 3 (each within the scatter of the next); then compound 2.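

In this assay, going by these compounds alone, the entry of 4,6-dimethoxy-1,3,5-triazin-2-yl on this amine nitrogen in a ring gives a 2.3-fold lower number from compound 3 to compound 4 (0.35 log units; beyond the scatter) and a 2.3-fold lower number from compound 1 to compound 4 (0.35 log units; beyond the scatter) and so is the first aryl exchange to pass the level shared by compound 1 and compound 3. The spread across these aryl groups widens to a 12-fold lower number from compound 2 to compound 4 (1.06 log units; beyond the scatter) and leaves compound 4 the strongest of the four. Nothing measured here accounts for this gain.

On these data alone, whether it follows the third hetero atom in the ring or the two methoxy groups stays open. So does whether an amino group or a longer alkoxy chain on the triazine would keep it.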